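Removing the dimethylamino group from compound 1

This account rests on a few compounds, and the source may have more. Where it says the series, first, only, none or still open, it means among the compounds named here.

Values so far in a functional assay on A549 cells (Homo sapiens) for inhibition, read by sulforhodamine B assay (on this read-out lower numbers stand for stronger inhibition of growth and higher numbers for weaker inhibition of growth), for three compounds:
Compound 1 `Cc1ccc2[nH]c(-c3ccc(-c4ccc(-c5ccc(N(C)C)cc5)cc4)cc3)nc2c1` gives 3510 nM
Compound 2 `CN(C)c1ccc(-c2ccc(-c3ccc(-c4nc5ccccc5[nH]4)cc3)cc2)cc1` gives 30100 nM
Compound 3 `CN(C)c1ccc(-c2ccc(-c3ccc(-c4nc5c(O)cccc5[nH]4)cc3)cc2)cc1` gives 7100 nM

Compound 1 has the lowest number of the three, so it inhibits growth most strongly. Compound 4 `Cc1ccc2[nH]c(-c3ccc(-c4ccc(-c5ccccc5)cc4)cc3)nc2c1` is still unmeasured. It has hydrogen in place of dimethylamino on an aromatic carbon and so ends in a plain phenyl. Among the measured compounds shown here, no measured step touches this group, so the only guides are changes at the other end of the molecule. These are an 8.6-fold higher number from compound 1 to compound 2 (0.93 log units; beyond the scatter) and a 2.0-fold higher number from compound 1 to compound 3 (0.31 log units; beyond the scatter), both upward, and a 4.2-fold lower number from compound 2 to compound 3 (0.63 log units; beyond the scatter), all modest. A modest rise is therefore expected in this assay, though the direction is uncertain, and the estimate means a 1.7-fold higher number from compound 1 to compound 4 (0.23 log units; within the scatter) for this change. For compound 4 the expected value is 6000 nM, within an estimated range of 1500 nM to 25000 nM.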

Compound 4, concentration for 50% growth inhibition: 3630 nM
Compound 4: middle estimate off by 1.7-fold (0.22 log units), on the high side; measured number inside the range.
By their numbers in this assay, from the lowest: compounds 1, 4 and 3 (each within the scatter of the next, the first and the last beyond it); then compound 2.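

In this assay, hydrogen in place of dimethylamino gives a 1.0-fold higher number from compound 1 to compound 4 (0.01 log units; within the scatter), so with the methyl-bearing end of compound 1 held fixed, this group makes no measurable difference to growth inhibition. The earlier steps shown here changed only the other end of the molecule and all lay beyond the scatter, whereas this one shows that the 4-(dimethylamino)phenyl end can become plain phenyl without a readable shift. Nothing measured here gives a reason for this.

Still open, as far as these compounds go, is whether a carboxylic acid or a primary amine at this position would move the number. From the compounds shown here alone, it is also open whether the same swap would behave alike on compound 2 or compound 3.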